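Carbamoyl to carboxy on the iodo compound

A few compounds are considered here, and "the series" means these few. Any claim that something is new, unique, unknown or untested is made for them only; others in the source may bear on it.

Within the data shown here, in a functional assay on MOLT-4 cells (Homo sapiens) (a lower number here means a stronger inhibitor, a higher number a weaker inhibitor), compound 1 `NC(=O)c1nn([C@@H]2O[C@H](CO)[C@@H](O)[C@H]2O)cc1I` gives 9100 nM, the only true number so far. Compound 2 `C#Cc1cn([C@@H]2O[C@H](CO)[C@@H](O)[C@H]2O)nc1C(N)=O` reads > 300000 nM, which is a limit of the assay. Among the measured compounds shown here, the one measured step, an at least 32-fold higher number from compound 1 to compound 2 (1.51 log units; beyond the scatter), puts ethynyl in place of iodo on an aromatic carbon and is large.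

Compound 3 `O=C(O)c1nn([C@@H]2O[C@H](CO)[C@@H](O)[C@H]2O)cc1I` keeps the iodo group and carries a different change: hydroxy in place of amino on a carbonyl carbon. This is hydroxy in place of amino on a carbonyl carbon, so carbamoyl becomes carboxy. For the measured compounds named here, no measured step covers this change. Compound 2 bears on it only indirectly, showing through an at least 32-fold higher number from compound 1 to compound 2 (1.51 log units; beyond the scatter) that a single change to compound 1 can cost much of its activity in this assay. A higher number is therefore expected, with the step estimated as a 16-fold higher number from compound 1 to compound 3 (1.22 log units; beyond the scatter). Compound 3 is estimated at 150000 nM, with an expected range of 30000 nM to 600000 nM.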

Compound 3, half-maximal inhibitory concentration: > 300000 nM
Compound 3 gave a limit, no number; the forecaster's own chance of this, stated with the estimate: 55%; middle value at least 2.0-fold (0.30 log units) away from the limit.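

Hydroxy in place of amino on a carbonyl carbon gives an at least 32-fold higher number from compound 1 to compound 3 (1.51 log units; beyond the scatter) in this assay, so the carbamoyl group, which the earlier compounds left unchanged, is a second place where one change removes measurable activity. Keeping the iodo group does not preserve activity without carbamoyl, and among the compounds shown only compound 1, which carries both groups, gives a true number. Compound 3 reads > 300000 nM, which is a limit and not a number, so the true size of this step stays unknown, and the same limit caps the series elsewhere: the limit of > 300000 nM in this assay, at which 2 of the 3 values shown sit.

From the compounds shown here alone, whether any other group is accepted in place of carbamoyl remains open, for example a methyl ester or a methylamide. Also open, going by these compounds, is whether a bromo or methyl group can replace iodo while carbamoyl stays in place.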